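Swapping Fluoro for Methoxy: Expected Loss in Cytotoxicity

The source may report more compounds than this note shows. Statements on the series, on what has been measured and on what is new or still open speak of the compounds shown alone.

Measured compounds:
- compound 1, `Cc1ccc(Cn2c(/C=C3\SC(=S)N(CC(=O)O)C3=O)nc3ccc(F)cc32)cc1`, in a functional assay on Raji cells (Homo sapiens) for cytotoxicity, read by MTT assay, with a stated time of 48 h (on this read-out lower numbers stand for stronger inhibition and higher numbers for weaker inhibition), gives 2440 nM
- compound 2, `COc1ccc2nc(/C=C3\SC(=S)N(CC(=O)O)C3=O)n(Cc3ccc(C)cc3)c2c1`, in this assay gives 10800 nM
- compound 3, `O=C(O)CN1C(=O)/C(=C/c2nc3cc(F)ccc3n2Cc2ccccc2F)SC1=S`, in this assay gives 20400 nM

Compound 1 and compound 2 share a core and differ in one place: methoxy in place of fluoro on an aromatic carbon. That change produced a 4.4-fold higher number from compound 1 to compound 2 (0.65 log units; beyond the scatter), a step beyond the usual scatter.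

Compound 3 carries a different core; how the core of compound 3 differs from the core of compound 1 is not broken down here. Compound 3 stands with the highest of the three numbers. Against compound 2 its value lies within the scatter, so no order is claimed between them; against compound 1 the gap is beyond the scatter.

Compound 4, `COc1ccc2c(c1)nc(/C=C1\SC(=S)N(CC(=O)O)C1=O)n2Cc1ccccc1F`, has not yet been measured. It differs from compound 3 by methoxy in place of fluoro on an aromatic carbon. This is the same change that was made from compound 1 to compound 2, the place of the change being described in the same words for both pairs; among these compounds it occurs twice in all.

The expectation for compound 4 rests on that single precedent: because the change gave a 4.4-fold higher number from compound 1 to compound 2 (0.65 log units; beyond the scatter), a step of similar direction and size is expected from compound 3 to compound 4, namely a 2.9-fold higher number from compound 3 to compound 4 (0.47 log units; beyond the scatter). Compound 4 is therefore estimated at 60000 nM, with a range from 20000 nM to 150000 nM, and there is a real chance that the assay reports only a limit rather than a number.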

Compound 4, half-maximal inhibitory concentration: 11500 nM
The estimate for compound 4 lay 5.2-fold (0.72 log units) above the measured number, and the stated range ends above it.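

In this assay, the change from fluoro to methoxy gave a 1.8-fold lower number from compound 3 to compound 4 (0.25 log units; within the scatter), so no order is claimed between the two. Set beside the earlier step, the same change did not keep its size from one core to the other: the same change on two cores in this assay, a 4.4-fold higher number (0.65 log units; beyond the scatter) from compound 1 to compound 2 and a 1.8-fold lower number (0.25 log units; within the scatter) from compound 3 to compound 4, 7.9-fold (0.89 log units) apart, beyond the scatter of two such steps. Within the data shown here, this shows that the step seen on the core of compound 1 cannot simply be carried over to the core of compound 3 in this series, but with only two pairs it does not show which part of the cores sets the two steps apart, nor what the change would do on any further core.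

The compounds shown leave open how other groups at this aromatic carbon, such as an amine, a chloro group or a hydroxyl, would read on either core. They also leave open how a longer chain bearing the carboxylic acid, or an ester in place of that acid, would read in this assay, since all four compounds carry the same acid chain.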